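The compounds below may be only part of what the source reports. "The series", "measured", "known", "first", "only" and "open" are said of these compounds alone.

Working notes on the series. The shared core is that of compound 1 `CC(=O)Oc1ccccc1C(=O)OCCO[N+](=O)[O-]`. Going by the values given here, in an ADME assay on a cell-free system (plasma, Homo sapiens) for metabolic stability, with Plasma (Rattus norvegicus) as the target (on this read-out lower numbers stand for a shorter-lived compound and higher numbers for a longer-lived compound), compound 1 gives 0.0267 h, the highest of the two numbers so far; its nearest neighbour is compound 2 `CC(=O)Oc1ccccc1C(=O)OC(C)CO[N+](=O)[O-]`, which in this assay gives 0.0244 h. Among the compounds with values here, the one measured step, a 1.1-fold lower number from compound 1 to compound 2 (0.04 log units; within the scatter), changes nothing beyond the scatter. Compound 3 `CC(=O)Oc1ccccc1C(=O)OCCCO[N+](=O)[O-]` is still to be measured in this assay. Compound 3 differs from compound 1 in (nitrooxy)methyl in place of nitrooxy on a saturated chain carbon, two bonds along the chain from an oxygen next to a carbonyl group. Within the data shown here, the only measured step that bears on it is the one from compound 1 to compound 2, a change on the same saturated chain that stayed within the scatter; nothing measured speaks directly to the chain itself being extended, so the expectation rests on that single step alone. With one small change on the same chain having left the number where it was, no step beyond the scatter is expected here either, and a 1.0-fold higher number from compound 1 to compound 3 (0.00 log units; within the scatter) is the estimated outcome. Compound 3 is therefore expected to give 0.027 h, with a range from 0.014 h to 0.055 h.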

Compound 3, half-life: 0.0372 h
The estimate for compound 3 lay 1.4-fold (0.14 log units) below the measured number; low and high end bracket the measured number.
By their numbers in this assay, from the lowest: compounds 2, 1 and 3 (each within the scatter of the next).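

In this assay the one-carbon extension at this position, a 1.4-fold higher number from compound 1 to compound 3 (0.14 log units; within the scatter), stays within the scatter, so (nitrooxy)methyl in place of nitrooxy on this saturated chain carbon, two bonds along the chain from an oxygen next to a carbonyl group, leaves the half-life unresolved from the starting number. Read with the methyl step, a 1.1-fold lower number from compound 1 to compound 2 (0.04 log units; within the scatter), it gives two different changes on the same saturated chain, a methyl on one chain carbon and a lengthening of the chain itself, and neither takes the read-out beyond the scatter, which the single earlier step could not show for a change of chain length. Nothing at hand accounts for these numbers.

Open, from the compounds shown here alone, is whether a longer chain carrying the nitrooxy group, or an amine or a carboxylic acid on this saturated chain carbon, would take the half-life beyond the scatter. The compounds shown also keep the rest of the core of compound 1 fixed, so the effect of a change elsewhere on the shared core cannot be judged from them.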